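The source may report more compounds than this note shows. Statements on the series, on what has been measured and on what is new or still open speak of the compounds shown alone.

In a functional assay on MCF7 cells (Homo sapiens) for cytotoxicity, read by MTT assay, with a stated time of 48 h (a higher number here means a weaker inhibitor, a lower number a stronger inhibitor), three compounds have been measured so far. Compound 1 `CCCCCCCCNC(=O)[C@@H](NC(=O)c1ccccc1)[C@@H](C)O` gives 111000 nM. Compound 2 `CCCCCCCCNC(=O)[C@@H](NC(=O)/C=C/c1ccccc1)[C@@H](C)O` gives 35100 nM, and compound 3 `CCCCCCCCCCCCNC(=O)[C@@H](NC(=O)c1ccccc1)[C@@H](C)O` gives 36600 nM. Each of the two changes made from compound 1 lowered the number: a 3.2-fold lower number from compound 1 to compound 2 (0.50 log units; beyond the scatter), and a 3.0-fold lower number from compound 1 to compound 3 (0.48 log units; beyond the scatter). Compound 3 and compound 2 give numbers within the usual scatter of each other, so nothing separates them, while compound 1 stands apart with a higher number.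

The next compound, compound 4 `CCCCCCCCCCCCNC(=O)[C@@H](NC(=O)c1cccs1)[C@@H](C)O`, keeps the whole of compound 3 except for one change: thiophen-2-yl in place of phenyl on a carbonyl carbon. Neither measured step touches this change directly. The step from compound 1 to compound 2 altered the group on the same carbonyl carbon, but by lengthening it rather than by exchanging one aromatic ring for another, and the step from compound 1 to compound 3 lies on the chain at the other end of the molecule. Going by the values given here, there is thus no measured step that sets the size of this exchange, and a swap of one small aromatic ring for another is expected to move the number only a little. Compound 4 is therefore estimated to give 35000 nM, with a range from 15000 nM to 90000 nM, which corresponds to an expected step of a 1.0-fold lower number from compound 3 to compound 4 (0.02 log units; within the scatter), within the scatter.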

Compound 4, half-maximal inhibitory concentration: 30400 nM
Compound 4: middle estimate off by 1.2-fold (0.06 log units), on the high side; the measured number falls inside the stated range.
By their numbers in this assay, from the lowest: compounds 4, 2 and 3 (each within the scatter of the next); then compound 1.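

In this assay, the exchange of phenyl for thiophen-2-yl on a carbonyl carbon gives a 1.2-fold lower number from compound 3 to compound 4 (0.08 log units; within the scatter) and so lies within the scatter, which means this assay does not tell these two rings apart on the core of compound 3. Going by these compounds alone, this is the first measured exchange of one aromatic ring for another at this place, and it shows that a six-membered ring of carbon only and a five-membered ring with a sulfur atom read alike here, whereas the earlier change on the same carbonyl carbon, to 2-phenylethenyl, gave a 3.2-fold lower number from compound 1 to compound 2 (0.50 log units; beyond the scatter) and lay beyond the scatter. No measured evidence bears on why the two rings read alike here.

The compounds shown leave open whether a ring with a nitrogen atom, such as pyridin-3-yl, or a phenyl ring carrying a chlorine atom would also fall within the scatter of compound 3. They also leave open whether thiophen-2-yl would read the same on the shorter chain of compound 1, or in place of the phenyl of the 2-phenylethenyl group of compound 2.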